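Swapping dimethylamino for ethylsulfanyl in compound 4

The source may report more compounds than this note shows. Statements on the series, on what has been measured and on what is new or still open speak of the compounds shown alone.

Measured in an ADME assay on microsomes from liver (Homo sapiens) for metabolic stability, with a stated time of 60 min, tested at 1 mg/mL; on this read-out higher numbers stand for fast clearance and lower numbers for slow clearance:
Compound 1 `COc1nc2ccc(Br)cc2cc1[C@@H](c1cncc(C)c1)[C@@](O)(CCN(C)C)c1cccc(F)c1` gives 56 mL.min-1.g-1
Compound 2 `COc1nc2ccc(Br)cc2cc1[C@@H](c1cccnc1N(C)C)[C@@](O)(CCN(C)C)c1cccc(F)c1` gives 45 mL.min-1.g-1
Compound 3 `COc1nc2ccc(Br)cc2cc1[C@@H](c1ccc(N(C)C)nc1)[C@@](O)(CCN(C)C)c1cccc(F)c1` gives 38 mL.min-1.g-1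

Compound 3 stands within the scatter of both other compounds, as shown by a 1.5-fold lower number from compound 1 to compound 3 (0.17 log units; within the scatter) and by a 1.2-fold lower number from compound 2 to compound 3 (0.07 log units; within the scatter). The next structure is compound 4 `CCSc1ccc([C@H](c2cc3cc(Br)ccc3nc2OC)[C@@](O)(CCN(C)C)c2cccc(F)c2)cn1`, and the change is ethylsulfanyl in place of dimethylamino on an aromatic carbon. In words, ethylsulfanyl replaces dimethylamino on an aromatic carbon, next to the ring nitrogen and para to a large group, turning 6-(dimethylamino)pyridin-3-yl into 6-(ethylsulfanyl)pyridin-3-yl.

Among the measured compounds shown here, no measured compound carries ethylsulfanyl, so no step speaks to this exchange directly. The closest evidence is the three steps among the measured compounds, which all alter the same pyridinyl group. These are the two steps above and a 1.2-fold lower number from compound 1 to compound 2 (0.09 log units; within the scatter), and none of them leaves the scatter. On this limited basis, no step beyond the scatter is expected in this assay, and no direction can be firmly assigned. The expected step is a 1.2-fold higher number from compound 3 to compound 4 (0.07 log units; within the scatter). For compound 4 the estimated value is 45 mL.min-1.g-1, with an expected range of 25 mL.min-1.g-1 to 80 mL.min-1.g-1. For the measured compounds named here, that range is kept wide, as the new group has no measured precedent here.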

Compound 4, intrinsic clearance in microsomes: 11 mL.min-1.g-1
Compound 4: middle estimate off by 4.1-fold (0.61 log units), on the high side; the whole stated range lies above it.
By their numbers in this assay, from the lowest: compound 4; then compounds 3, 2 and 1 (each within the scatter of the next).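

In this assay, among the compounds shown here, this is the first exchange to leave the scatter (a 3.5-fold lower number from compound 3 to compound 4 (0.54 log units; beyond the scatter)), and it happens on an aromatic carbon next to the ring nitrogen and para to a large group. The group that leaves and the group that enters have the same count of heavy atoms and of hydrogen-bond acceptors, so the exchange changes the kind of group rather than those counts, and the step is also beyond the scatter against the other two pyridinyl groups (a 4.1-fold lower number from compound 2 to compound 4 (0.61 log units; beyond the scatter); a 5.1-fold lower number from compound 1 to compound 4 (0.71 log units; beyond the scatter)), which leaves compound 4 with the lowest number of the four, while the three earlier compounds stay within the scatter of one another. Nothing available here bears on what lies behind this step.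

The compounds shown leave open whether the step goes with the sulfur or with the ethyl chain, which a methylsulfanyl, propylsulfanyl or ethoxy group at this position could help to separate. They also leave open whether ethylsulfanyl would give a similar step elsewhere on the ring, as in a 2-(ethylsulfanyl)pyridin-3-yl group.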